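A few compounds are considered here, and "the series" means these few. Any claim that something is new, unique, unknown or untested is made for them only; others in the source may bear on it.

Compound 1 `O=C(/C=C/c1ccccc1Oc1ncnc2ccc(Cl)cc12)/C=C/c1cccc(Cl)c1Cl`: 5210 nM
Compound 2 `O=C(/C=C/c1ccc(Oc2ncnc3ccc(Cl)cc23)cc1)/C=C/c1c(Cl)cccc1Cl`: 6770 nM

Both compounds were tested in a functional assay on MGC-803 cells (Homo sapiens) for inhibition, read by MTT assay, with a stated time of 72 h; on this read-out lower numbers stand for stronger inhibition and higher numbers for weaker inhibition. Compound 1 gives 5210 nM and compound 2 gives 6770 nM. Compound 2 carries the higher of the two numbers, but the gap between compound 2 and compound 1 lies within the scatter of repeated measurements, so the two cannot be told apart on these numbers alone.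

Compound 3 `O=C(/C=C/c1ccc(Oc2ncnc3ccc(Cl)cc23)cc1)/C=C/c1ccc(Cl)c([N+](=O)[O-])c1` has not yet been measured. It differs from compound 2 in one place: 4-chloro-3-nitrophenyl in place of 2,6-dichlorophenyl on a double-bonded chain carbon bound to a double-bonded chain carbon. Among the measured compounds shown here, no measured pair shows this change, so its effect has to be guessed from what little is available. For the measured compounds named here, with only two numbers, both of similar size, the middle of the range seen so far is the most honest starting point. The step from compound 2 to compound 3 is expected to be small, in either direction, and probably not beyond the scatter: a 1.1-fold lower number from compound 2 to compound 3 (0.05 log units; within the scatter). Compound 3 is therefore expected to give about 6000 nM in this assay, with a plausible range from 2500 nM to 15000 nM.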

Compound 3, half-maximal inhibitory concentration: 7190 nM
Compound 3: the middle estimate sits 1.2-fold (0.08 log units) below what was measured, within the range that was stated.
By their numbers in this assay, from the lowest: compounds 1, 2 and 3 (each within the scatter of the next).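

In this assay, putting 4-chloro-3-nitrophenyl in place of 2,6-dichlorophenyl on a double-bonded chain carbon bound to a double-bonded chain carbon gives a 1.1-fold higher number from compound 2 to compound 3 (0.03 log units; within the scatter) and so leaves compound 2 and compound 3 indistinguishable. Among the compounds shown here, this is the first reading of a single exchange, and it shows that this place accepts a group with 10 heavy atoms instead of 8, and with 2 hydrogen-bond acceptors instead of 0, without a readable difference in the number. No separate measurement on these compounds helps to interpret this result.

On these data alone, both groups compared here are phenyl rings that carry chlorine, so it remains open whether plain phenyl, or a group of another kind such as an amine or a carboxylic acid, would give a number beyond the scatter at this place. This single step also says nothing about the rest of the molecule, such as what would follow if a methoxy group took the place of the chlorine on the shared core.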